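Moving the nitro group on the cinnamamide tail of compound 1

The source may hold more compounds than are shown below. What is called first, only, known or untested is meant among the compounds shown, and "the series" means these compounds.

Measured compounds:
compound 1, `O=C(/C=C/c1ccc([N+](=O)[O-])cc1)Nc1cc2c(Nc3ccc(F)c(Cl)c3)ncnc2cc1O[C@H]1CCOC1`, 22800 nM
compound 2, `COc1ccc(OC)c(/C=C/C(=O)Nc2cc3c(Nc4ccc(F)c(Cl)c4)ncnc3cc2OC)c1`, 28600 nM
compound 3, `COc1cc2ncnc(Nc3ccc(F)c(Cl)c3)c2cc1NC(=O)/C=C/c1ccccc1[N+](=O)[O-]`, 14300 nM

All three were tested in a functional assay on PC-3 cells (Homo sapiens) for cytotoxicity, read by MTT assay, with a stated time of 72 h; a lower number here means a stronger inhibitor, a higher number a weaker inhibitor. Compound 1, with a 4-nitrophenyl on its chain, gives 22800 nM, and this sits among the values of compound 2 and compound 3 with neither gap larger than the usual scatter, so the three compounds cannot be told apart.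

Compound 4, `O=C(/C=C/c1ccccc1[N+](=O)[O-])Nc1cc2c(Nc3ccc(F)c(Cl)c3)ncnc2cc1O[C@H]1CCOC1`, differs from compound 1 only as follows: 2-nitrophenyl in place of 4-nitrophenyl on a double-bonded chain carbon bound to a double-bonded chain carbon. Among the measured compounds shown here, no measured pair shows exactly this exchange. The nearest guide is the step from compound 2 to compound 3, which brought in the same 2-nitrophenyl on a different core and gave a 2.0-fold lower number from compound 2 to compound 3 (0.30 log units; within the scatter). Compound 4 is therefore expected to stay close to compound 1, with a step of a 1.4-fold lower number from compound 1 to compound 4 (0.15 log units; within the scatter) at most. The estimate for compound 4 is 16000 nM, between 7000 nM and 40000 nM.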

Compound 4, half-maximal inhibitory concentration: 7760 nM
Estimate against measurement, compound 4: 2.1-fold (0.31 log units) above; the range from low to high includes it.
By their numbers in this assay, from the lowest: compounds 4, 3, 1 and 2 (each within the scatter of the next, the first and the last beyond it).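

Placing 2-nitrophenyl in place of 4-nitrophenyl on this chain carbon gives in this assay a 2.9-fold lower number from compound 1 to compound 4 (0.47 log units; beyond the scatter) and is the first step among these compounds to pass the scatter. The atom counts do not change, so the arrangement of the nitrophenyl group alone can shift this number. The other new change, oxolan-3-yl in place of methyl on the oxygen, gives a 1.8-fold lower number from compound 3 to compound 4 (0.27 log units; within the scatter) and so cannot be told apart from no change.

From the compounds shown here alone, whether an amine or a carboxylic acid in place of the nitro group would keep this number stays open. Nothing measured here explains why the position of the nitro group matters.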